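Series notes: compound 4 in the cytotoxicity read-out

The source may report more compounds than this note shows. Statements on the series, on what has been measured and on what is new or still open speak of the compounds shown alone.

Measured so far in an ADME assay on L6 cells (Rattus norvegicus) for cytotoxicity; a higher number here means a weaker inhibitor, a lower number a stronger inhibitor: compound 1 `Nc1ccc(NC2=NCCN2)cc1` gives > 423000 nM, which is a limit of the assay. Compound 2 `N=C(N)Nc1ccc(Nc2ccccc2)cc1` gives 49500 nM. Compound 3 `c1ccc(Nc2ccc(NC3=NCCN3)cc2)cc1` gives 90700 nM.

Compound 1 therefore stands only at the limit (the limit of > 423000 nM in this assay, at which 1 of the 3 values shown sits), and no number is known for it. Compound 4 `c1cc(N2CCCCC2)ccc1NC1=NCCN1` differs from compound 1 by piperidin-1-yl in place of amino on an aromatic carbon. Within the data shown here, the measured step that bears on this change is an at least 4.6-fold lower number from compound 1 to compound 3 (0.66 log units; beyond the scatter), the only step in which a larger group enters at the edge of the shared core. The step of a 1.8-fold higher number from compound 2 to compound 3 (0.26 log units; within the scatter) touches a different part and is within the scatter. A lower number beyond the scatter is therefore expected for compound 4, an at least 4.2-fold lower number from compound 1 to compound 4 (0.62 log units; beyond the scatter). Compound 4 is estimated at 100000 nM in this assay, between 40000 nM and 423000 nM, with a real chance that again only a limit is reported.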

Compound 4, half-maximal inhibitory concentration: > 283000 nM
Compound 4: only a limit was reported; the forecaster's own chance of this, stated with the estimate: 30%; at least 2.8-fold (0.45 log units) between middle value and limit.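

In this assay compound 4 gives > 283000 nM as a limit only. Compound 1 also stands at a limit, so the step between compound 1 and compound 4 cannot be read. On these data alone, whether piperidin-1-yl in place of amino moves the number, and in which direction, stays open.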